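The source may report more compounds than this note shows. Statements on the series, on what has been measured and on what is new or still open speak of the compounds shown alone.

Styryl sulfonate esters of methoxyphenols, three measured so far. In an assay on U2OS cells for activation of nuclear factor erythroid 2-related factor 2 (Homo sapiens), read by chemiluminescence, with a stated time of 6 h (on this read-out lower numbers stand for an effect already at smaller amounts and higher numbers for an effect only at larger amounts of compound), compound 1 `COc1ccc(OS(=O)(=O)/C=C/c2ccccc2)cc1` gives 1480 nM and compound 3 `COc1cccc(OS(=O)(=O)/C=C/c2cccc(Cl)c2)c1` gives 943 nM. Compound 2 `COc1ccccc1OS(=O)(=O)/C=C/c1ccccc1Cl` gives 76 nM in this assay, the lowest of the three numbers; its gap to compound 3 and its larger gap to compound 1 both lie beyond the scatter. Compound 4 `COc1ccccc1OS(=O)(=O)/C=C/c1ccc(Cl)cc1` is the next candidate; it differs from compound 2 by 4-chlorophenyl in place of 2-chlorophenyl on a double-bonded chain carbon bound to a double-bonded chain carbon. Going by the values given here, no measured pair isolates this change, so its size in this assay is open. An upward step of moderate size is expected, a 3.3-fold higher number from compound 2 to compound 4 (0.52 log units; beyond the scatter), given that compound 2 already holds the lowest number at 76 nM. Compound 4 is expected to give about 250 nM in this assay, within 60 nM to 1000 nM.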

Compound 4, half-maximal effective concentration: 1330 nM
Compound 4: the middle estimate sits 5.3-fold (0.73 log units) below what was measured; measured number above the stated range.
By their numbers in this assay, from the lowest: compound 2; then compounds 3, 4 and 1 (each within the scatter of the next).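

With the same atoms present, 4-chlorophenyl in place of 2-chlorophenyl on a double-bonded chain carbon bound to a double-bonded chain carbon gives an 18-fold higher number from compound 2 to compound 4 (1.24 log units; beyond the scatter) in this assay, a large step. This first isolated pair shows that the low number of compound 2 depends on where the chlorine sits on the aromatic ring, not merely on its presence. Nothing available accounts for the size of this step.

From the compounds shown here alone, whether an amine or a nitrile in place of that chlorine would keep the low number remains open. Also open, going by these compounds, is whether 2-chlorophenyl would give a similarly low number on the cores of compound 1 and compound 3.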